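Swapping the amide ring of a histamine receptor ligand

The compounds below may be only part of what the source reports. "The series", "measured", "known", "first", "only" and "open" are said of these compounds alone.

Compound 1 `Cc1cc(N2CC[C@H](N3CCC[C@@H]3C)C2)ccc1NC(=O)C1C(C)(C)C1(C)C`: 0.55 nM
Compound 2 `Cc1cc(N2CC[C@H](N3CCC[C@@H]3C)C2)ccc1NC(=O)C1CCOCC1`: 0.97 nM

In an assay on CHO cells for displacement of a labelled ligand from histamine receptor H3 (Macaca mulatta) (on this read-out lower numbers stand for stronger inhibition and higher numbers for weaker inhibition), compound 1 gives 0.55 nM and compound 2 gives 0.97 nM. Going by the values given here, compound 2 holds the higher of these two numbers, with compound 1 as its only neighbour. Compound 3 `Cc1cc(N2CC[C@H](N3CCC[C@@H]3C)C2)ccc1NC(=O)C1CC2CCC1C2` differs from compound 2 by a group of 7 heavy atoms (7 carbon; 2 five-membered non-aromatic rings of carbon only) in place of a group of 6 heavy atoms (5 carbon, 1 oxygen; one six-membered non-aromatic ring with 1 hetero atom), on a carbonyl carbon. Among the compounds with values here, the one measured step at this carbonyl carbon, a 1.8-fold higher number from compound 1 to compound 2 (0.25 log units; within the scatter), stayed within the scatter, so no shift beyond the scatter is expected from the new ring either. Compound 3 is therefore estimated at 0.7 nM, between 0.3 nM and 1.8 nM, an expected step of a 1.4-fold lower number from compound 2 to compound 3 (0.14 log units; within the scatter).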

Compound 3, inhibition constant: 0.55 nM
Compound 3: the middle estimate sits 1.3-fold (0.10 log units) above what was measured; low and high end bracket the measured number.
By their numbers in this assay, from the lowest: compounds 1, 3 and 2 (each within the scatter of the next).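

In this assay, a third ring group on the carbonyl carbon also stays within the scatter: the steps are a 1.8-fold lower number from compound 2 to compound 3 (0.25 log units; within the scatter) and no change at the digits printed from compound 1 to compound 3 (within the scatter). The entering group has no hydrogen-bond acceptor, while oxan-4-yl has one, so across these three compounds, removing the ring oxygen leaves the number within the scatter. No available evidence explains this. On these data alone, an amine, a carboxylic acid or a longer chain on this carbonyl carbon remains an open case, so how far this flat picture extends is unknown.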